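The compounds below may be only part of what the source reports. "The series", "measured", "known", "first", "only" and "open" are said of these compounds alone.

Working notes on the nitropyrimidine series, measured in a functional assay on HepG2 cells (Homo sapiens) for antiproliferative activity, read by MTT assay, with a stated time of 48 h; on this read-out higher numbers stand for weaker inhibition and lower numbers for stronger inhibition.

Of the compounds shown here, three have numbers so far. Compound 1 `CCOC(=O)CN(Cc1ccccc1)c1nc(NCc2ccccc2)ncc1[N+](=O)[O-]` gives 21000 nM in this assay. Compound 2 `COC(=O)CN(C)c1nc(Nc2ccc(Cl)cc2)ncc1[N+](=O)[O-]` gives 49800 nM in this assay. Compound 3 `CCOC(=O)CNc1nc(Nc2ccccc2)ncc1[N+](=O)[O-]` is reported in this assay only as a limit, > 100000 nM, so no number is known for it; this is the limit of > 100000 nM in this assay, at which 1 of the 3 values shown sits. For the measured compounds named here, compound 3 therefore stands at the weak end of what has been seen, with no measured step joining it to compound 1 or compound 2.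

Compound 4 `CCOC(=O)CNc1nc(Nc2ccc(Cl)cc2)ncc1[N+](=O)[O-]` has not been measured in this assay. It differs from compound 3 by chloro in place of hydrogen on an aromatic carbon, the same change that reads anilino to (4-chlorophenyl)amino. Going by the values given here, no measured pair in the set isolates this change, so the size of the step is not known from the data. Compound 2 carries the same (4-chlorophenyl)amino group and gives 49800 nM, which is a number rather than a limit.

On that basis compound 4 is expected to sit near 90000 nM, within 30000 nM to 300000 nM. The expected step of an at least 1.1-fold lower number from compound 3 to compound 4 (0.04 log units; that floor lies within the scatter) is small and may again end at the limit.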

Compound 4, half-maximal inhibitory concentration: > 100000 nM
Compound 4 ended at the assay's limit; the forecaster's own chance of this, stated with the estimate: 55%; middle value at least 1.1-fold (0.04 log units) from the limit.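

In this assay compound 4 gives > 100000 nM, a limit and not a number, so chloro in place of hydrogen on an aromatic carbon, para to a large group, does not by itself bring this secondary-amine ethyl ester to a readable value, and the step from compound 3 cannot be read, since both ends are limits. For the compounds shown here, with the (4-chlorophenyl)amino group held in place, ((ethoxycarbonyl)methyl)amino in place of ((methoxycarbonyl)methyl)(methyl)amino gives an at least 2.0-fold higher number from compound 2 to compound 4 (0.30 log units; that floor lies within the scatter), the first step that can be read at all, though it is only a floor, so the (4-chlorophenyl)amino group alone does not account for the number seen for compound 2. The limit is now shared: the limit of > 100000 nM in this assay, at which 2 of the 4 values shown sit.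

As far as these compounds go, the change from compound 2 to compound 4 alters both the ester and the methyl on the amine nitrogen, so which of the two carries the step remains open. Also open, from the compounds shown here alone, is whether a carboxylic acid in place of the ester, or a benzyl group on that nitrogen with the (4-chlorophenyl)amino group kept, would give a number rather than a limit.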